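Second methyl on the benzoxazole: notes toward compound 4

A few compounds are considered here, and "the series" means these few. Any claim that something is new, unique, unknown or untested is made for them only; others in the source may bear on it.

Measured so far in an assay on CHO cells for displacement of a labelled ligand from prostaglandin E2 receptor EP2 subtype (Mus musculus), read by scintillation counting, with a stated time of 60 min; a lower number here means a stronger inhibitor, a higher number a weaker inhibitor:
- compound 1, `O=C(O)c1csc(SCCN2C(=O)CC[C@@H]2/C=C/[C@@H](O)Cc2cccc(-c3ccccc3)c2)n1`: 3 nM
- compound 2, `Cc1ccc2oc(-c3cccc(C[C@H](O)/C=C/[C@H]4CCC(=O)N4CCSc4nc(C(=O)O)cs4)c3)nc2c1`: 21 nM
- compound 3, `Cc1cccc2oc(-c3cccc(C[C@H](O)/C=C/[C@H]4CCC(=O)N4CCSc4nc(C(=O)O)cs4)c3)nc12`: 22 nM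

Compound 3 carries the highest of the three numbers in this assay, but one of its gaps is only a 1.0-fold higher number from compound 2 to compound 3 (0.02 log units; within the scatter), which is within the scatter. The other gap is a 7.3-fold higher number from compound 1 to compound 3 (0.87 log units; beyond the scatter), beyond the scatter, and compound 2 shows the same pattern against compound 1 with a 7.0-fold higher number from compound 1 to compound 2 (0.85 log units; beyond the scatter).

Compound 4, `Cc1cc(C)c2oc(-c3cccc(C[C@H](O)/C=C/[C@H]4CCC(=O)N4CCSc4nc(C(=O)O)cs4)c3)nc2c1`, differs from compound 3 by 5,7-dimethyl-1,3-benzoxazol-2-yl in place of 4-methyl-1,3-benzoxazol-2-yl on an aromatic carbon. Two of the measured steps bear on it. The step from compound 2 to compound 3 moves one methyl on the benzoxazole and gives a 1.0-fold higher number from compound 2 to compound 3 (0.02 log units; within the scatter), within the scatter. The steps from compound 1 to compound 2 and to compound 3 exchange phenyl for a methylbenzoxazole and are both modest. For the measured compounds named here, no measured step adds a second methyl to the benzoxazole, so that part is untested. The expectation is therefore a step of a 1.1-fold higher number from compound 3 to compound 4 (0.06 log units; within the scatter), not beyond the scatter. Compound 4 is estimated at 25 nM in this assay, with a range from 9 nM to 70 nM.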

Compound 4, inhibition constant: 24 nM
Beside the measured number, compound 4's estimate is 1.0-fold (0.02 log units) above it; the range from low to high includes it.
By their numbers in this assay, from the lowest: compound 1; then compounds 2, 3 and 4 (each within the scatter of the next).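

Working notes on the series: a second methyl on the benzoxazole has now been read in this assay, and adding methyl in place of hydrogen on an aromatic carbon gives a 1.1-fold higher number from compound 2 to compound 4 (0.06 log units; within the scatter) while the swap of 4-methyl-1,3-benzoxazol-2-yl for 5,7-dimethyl-1,3-benzoxazol-2-yl gives a 1.1-fold higher number from compound 3 to compound 4 (0.04 log units; within the scatter) so that compounds 2, 3 and 4 cannot be told apart at this position. The extra methyl does not close the gap to the phenyl compound, which stands at an 8.0-fold higher number from compound 1 to compound 4 (0.90 log units; beyond the scatter) and so remains of the same modest kind as the gaps from compound 1 to the two monomethyl compounds. Nothing available explains why the number stays flat across these three benzoxazoles.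

Open, from the compounds shown here alone, is whether this flatness holds for substituents other than methyl on the benzoxazole, such as a methoxy group, a chlorine atom or an amine. Also open, going by these compounds, is whether any benzoxazole in place of the phenyl can reach the level of compound 1 at 3 nM in this assay or whether the unsubstituted 1,3-benzoxazol-2-yl group already sits with compounds 2, 3 and 4.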